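This account rests on a few compounds, and the source may have more. Where it says the series, first, only, none or still open, it means among the compounds named here.

Among the compounds with values here, in a functional assay on PC-3 cells (Homo sapiens) for cytotoxicity, with a stated time of 48 h (on this read-out lower numbers stand for stronger inhibition and higher numbers for weaker inhibition), only two readings exist so far: compound 1 `COc1cc(OC)c(C(=O)/C=C/c2ccccc2SC)c(OC)c1` gives 7600 nM and compound 2 `COc1cc(O)c(C(=O)/C=C/c2ccccc2OC)c(OC)c1` gives 9600 nM under the same conditions. These two values lie within the scatter of each other, so compound 2 stands level with compound 1 and the pair cannot be ranked. The next compound, compound 3 `COc1cc(O)c(C(=O)/C=C/c2ccccc2SC)c(OC)c1`, shares the core of compound 2. The change methylsulfanyl in place of methoxy on an aromatic carbon is methylsulfanyl in place of methoxy on an aromatic carbon, ortho to a large group. Within the data shown here, no pair of measured compounds shows this exchange alone, since compound 1 and compound 2 differ in more than one place. Among the measured compounds shown here, the only guide is that compound 1, which already carries methylsulfanyl, reads 7600 nM within the scatter of compound 2. No step beyond the scatter is therefore expected in this assay on going to compound 3. For compound 3 the estimate is 6000 nM as the expected value, with 2000 nM to 18000 nM as its expected range. The estimated 1.6-fold lower number from compound 2 to compound 3 (0.20 log units; within the scatter) is expected to stay within the scatter.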

Compound 3, half-maximal inhibitory concentration: 8700 nM
Compound 3: middle estimate off by 1.5-fold (0.16 log units), on the low side, within the range that was stated.
By their numbers in this assay, from the lowest: compounds 1, 3 and 2 (each within the scatter of the next).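

In this assay, the exchange of methoxy for methylsulfanyl on an aromatic carbon, ortho to a large group, can now be read on its own: it gives a 1.1-fold lower number from compound 2 to compound 3 (0.04 log units; within the scatter) and so does not separate the two groups at this position on this core. The second single change, hydrogen in place of methyl on an oxygen on an aromatic ring, gives a 1.1-fold higher number from compound 1 to compound 3 (0.06 log units; within the scatter) with methylsulfanyl in place, so that oxygen substituent does not separate compound 1 and compound 3 in this read-out either. Nothing available bears on why these readings stay within the scatter of one another.

From the compounds shown here alone, whether a group of another kind at the same aromatic carbon, such as an amine, a carboxylic acid or a longer alkylsulfanyl chain, would give a step beyond the scatter remains open. It is also open whether the same two exchanges would stay within the scatter on a different core or in a read-out other than this assay, as the compounds shown cover only this one core and this one cell line.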